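Notes on the step from compound 3 to compound 4

The compounds below may be only part of what the source reports. "The series", "measured", "known", "first", "only" and "open" are said of these compounds alone.

Compound 3 `Fc1cc2nc(-c3cncnc3NCCC(F)(F)F)n(C3CC3)c2cc1F` gives the lowest number of the three measured in an assay on cells for inhibition of cytochrome P450 11B2, mitochondrial (Homo sapiens), read by HPLC, with a stated time of 90 min (a lower number here means a stronger inhibitor, a higher number a weaker inhibitor), at 3 nM. Compound 1 `CCc1ncncc1-c1nc2cc(F)c(F)cc2n1C1CC1` gives 8 nM and compound 2 `CN(C)c1ncncc1-c1nc2cc(F)c(F)cc2n1C1CC1` gives 29 nM. Compound 4 `Fc1cc2nc(-c3cncnc3C(F)F)n(C3CC3)c2cc1F` differs from compound 3 in one place: difluoromethyl in place of (3,3,3-trifluoropropyl)amino on an aromatic carbon. The measured steps that bear on this change are a 2.7-fold lower number from compound 1 to compound 3 (0.43 log units; beyond the scatter) and a 9.7-fold lower number from compound 2 to compound 3 (0.99 log units; beyond the scatter); both put the (3,3,3-trifluoropropyl)amino group ahead of a smaller group with no hydrogen-bond donor at this carbon, while a 3.6-fold higher number from compound 1 to compound 2 (0.56 log units; beyond the scatter) shows that such smaller groups also differ among themselves. Removing the group that carried both gains is therefore expected to give a modestly higher number in this assay, roughly a 3.3-fold higher number from compound 3 to compound 4 (0.52 log units; beyond the scatter). Compound 4 is expected to give about 10 nM, within 4 nM to 30 nM.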

Compound 4, half-maximal inhibitory concentration: 18 nM
Compound 4: the middle estimate sits 1.8-fold (0.26 log units) below what was measured, and the stated range covers the measured number.
By their numbers in this assay, from the lowest: compound 3; then compound 1; then compounds 4 and 2 (each within the scatter of the next).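

Difluoromethyl does not match (3,3,3-trifluoropropyl)amino at this aromatic carbon in this assay (a 6.0-fold higher number from compound 3 to compound 4 (0.78 log units; beyond the scatter)). Against the smaller groups, it trails ethyl (a 2.3-fold higher number from compound 1 to compound 4 (0.35 log units; beyond the scatter)) and cannot be separated from dimethylamino (a 1.6-fold lower number from compound 2 to compound 4 (0.21 log units; within the scatter)), so fluorine on the small group brings no gain over ethyl here. No measurement at hand accounts for these differences.

On these data alone, whether the advantage of compound 3 rests on the amine hydrogen or on the fluorinated chain stays open. A plain propylamino group and a trifluoromethyl group at this carbon would bear on that question.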